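The compounds below may be only part of what the source reports. "The series", "measured", "known", "first", "only" and "open" are said of these compounds alone.

Compound 1 `Cc1nc(C)n2c(O)nncc12` is one of three compounds examined in a functional assay for inhibition, with Homo sapiens as the target; on this read-out lower numbers stand for stronger inhibition and higher numbers for weaker inhibition. For compound 1 the read-out is only a limit, > 48000 nM. Compound 2 `CCc1nnc(O)n2c(C)nc(C)c12` likewise returns only a limit, > 48000 nM. Compound 3 `Cc1nc(C(C)(C)C)n2c(O)nncc12` gives a number, 31000 nM. The move from compound 1 to compound 2 is a step that the two limits leave unreadable from compound 1 to compound 2, and the move from compound 1 to compound 3 is an at least 1.5-fold lower number from compound 1 to compound 3 (0.18 log units; that floor lies within the scatter). Compound 1 therefore stands at a limit rather than at a number, a position described by the limit of > 48000 nM in this assay, at which 2 of the 3 values shown sit.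

Compound 4 `C=CCSc1nncc2c(C)nc(C)n12` differs from compound 1 in one place: allylsulfanyl in place of hydroxy on an aromatic carbon. Among the compounds with values here, neither measured step touches the hydroxy, and only the step to compound 3 yields a number at all, so the measured evidence bears on this change only loosely. Because of an at least 1.5-fold lower number from compound 1 to compound 3 (0.18 log units; that floor lies within the scatter) a gain of comparable modest size is plausible, though its floor lies within the scatter. Compound 4 is expected to give 30000 nM, with a range from 8000 nM to 100000 nM. This amounts to an expected at least 1.6-fold lower number from compound 1 to compound 4 (0.20 log units; that floor lies within the scatter).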

Compound 4, half-maximal inhibitory concentration: 59000 nM
For compound 4 the middle estimate is 2.0-fold (0.29 log units) below the measured one, within the range that was stated.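

The change from compound 1 to compound 4 gives no readable step, since compound 1 stands only at a limit: the limit of > 48000 nM in this assay, at which 2 of the 4 values shown sit.

The compounds shown leave open how far, and in which direction, allylsulfanyl in place of hydroxy moves the read-out.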